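One Step Longer: The Chain of Compound 3

The source may hold more compounds than are shown below. What is called first, only, known or untested is meant among the compounds shown, and "the series" means these compounds.

- Compound 1 `COc1ccc(Nc2nc(Nc3cnn(CCCCCCC(=O)NO)c3)ncc2Cl)cc1` gives 620 nM
- Compound 2 `O=C(CCCCCn1cc(Nc2ncc(Cl)c(Nc3ccccc3Cl)n2)cn1)NO` gives 1810 nM

Both values come from a functional assay on K562 cells (Homo sapiens) for antiproliferative activity, read by MTT assay, with a stated time of 48 h; on this read-out higher numbers stand for weaker inhibition and lower numbers for stronger inhibition. Compound 2 stands at the higher of the two numbers, 1810 nM, which makes it the weaker inhibitor of the pair, and the gap to compound 1 lies beyond the scatter.

Compound 3 `O=C(CCCCCCn1cc(Nc2ncc(Cl)c(Nc3ccccc3Cl)n2)cn1)NO` has not yet been measured. It differs from compound 2 by a single change (hydroxycarbamoyl)methyl in place of hydroxycarbamoyl on a saturated chain carbon, five bonds along the chain from an aromatic nitrogen. The chain ending in the hydroxycarbamoyl group simply gets longer.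

Among the compounds with values here, no measured pair shows what such a lengthening does alone, so any forecast in this assay is a judgement. A small move toward stronger inhibition seems most likely, probably within the scatter. Within the data shown here, the lower number of compound 1, 620 nM, shows only that values under that of compound 2 occur here. The expected change is a 1.8-fold lower number from compound 2 to compound 3 (0.26 log units; within the scatter). For compound 3 the estimated value is 1000 nM, with an expected range from 400 nM to 2500 nM.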

Compound 3, half-maximal inhibitory concentration: 860 nM
For compound 3 the middle estimate is 1.2-fold (0.07 log units) above the measured one; the measured number falls inside the stated range.
By their numbers in this assay, from the lowest: compounds 1 and 3 (each within the scatter of the next); then compound 2.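

In this assay, within the data shown here, lengthening the chain, with (hydroxycarbamoyl)methyl in place of hydroxycarbamoyl on a saturated chain carbon, five bonds along the chain from an aromatic nitrogen, gives a 2.1-fold lower number from compound 2 to compound 3 (0.32 log units; beyond the scatter) and so provides the first direct reading of what chain length alone does in these compounds. The second comparison holds that longer chain fixed and puts 2-chlorophenyl in place of 4-methoxyphenyl on a nitrogen on an aromatic ring, which gives a 1.4-fold higher number from compound 1 to compound 3 (0.14 log units; within the scatter) and means that, with this chain, this assay does not separate the two aromatic groups. The chain step is modest, and no accompanying measurement offers an explanation for it.

A single lengthening cannot show whether the trend continues, so a still longer chain, such as one ending in 4-(hydroxycarbamoyl)butyl on the chain carbon named above, might lower the number further, level off or raise it. From the compounds shown here alone, it is also open how much of the activity depends on the end group itself, which a carboxylic acid or a primary amide in place of hydroxycarbamoyl at the end of the same chain would test.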